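Removing One Methyl Group from Compound 2

The source may hold more compounds than are shown below. What is called first, only, known or untested is meant among the compounds shown, and "the series" means these compounds.

- Compound 1 `C=C/C=C\[C@H](C)[C@H](OC(N)=O)[C@@H](C)[C@H](O)[C@@H](C)C/C(C)=C\[C@H](C)[C@@H](O)[C@@H](C)/C=C\CCc1ccc(Oc2ccccc2)cc1`: 4000 nM
- Compound 2 `C=C/C=C\[C@H](C)[C@H](OC(N)=O)[C@@H](C)[C@H](O)[C@@H](C)C/C(C)=C\[C@H](C)[C@@H](O)[C@@H](C)/C=C\CCc1ccc(C)c(F)c1`: 1000 nM

In a functional assay on MCF7 cells (Homo sapiens) for cytotoxicity (a higher number here means a weaker inhibitor, a lower number a stronger inhibitor), compound 2 has the lower of the two numbers at 1000 nM, and compound 1 stands at 4000 nM. That gap lies beyond the usual scatter, so compound 2 is the stronger inhibitor of the pair.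

Compound 3 `C=C/C=C\[C@H](C)[C@H](OC(N)=O)[C@@H](C)[C@H](O)[C@@H](C)C/C(C)=C\[C@H](C)[C@@H](O)[C@@H](C)/C=C\CCc1cccc(F)c1` has not yet been measured. Its change from compound 2 is small: hydrogen in place of methyl on an aromatic carbon. In words, hydrogen takes the place of methyl on an aromatic carbon, ortho to a fluoro group and para to a large group.

Among the compounds with values here, no measured pair shows this change alone, so the data give no direct guide to its size. The expected result in this assay is a 1.5-fold higher number from compound 2 to compound 3 (0.18 log units; within the scatter), a slight rise that would stay within the scatter. The estimated value for compound 3 is 1500 nM, with an expected range of 500 nM to 5000 nM.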

Compound 3, half-maximal inhibitory concentration: 370 nM
The estimate for compound 3 lay 4.1-fold (0.61 log units) above the measured number; the whole stated range lies above it.
By their numbers in this assay, from the lowest: compound 3; then compound 2; then compound 1.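

Within the data shown here, this step gives the first direct reading of this position. In this assay, hydrogen in place of methyl on the aromatic carbon ortho to a fluoro group and para to a large group gives a 2.7-fold lower number from compound 2 to compound 3 (0.43 log units; beyond the scatter) and a change beyond the scatter. The methyl group is therefore not required for activity in this pair, and the 3-fluorophenyl end gives a stronger inhibitor than the 3-fluoro-4-methylphenyl end, though nothing measured here explains this result.

Going by these compounds, it remains open whether a methoxy group, a chlorine atom or an amine on this same carbon would lower the number further or raise it again. Also open, on these data alone, is what the fluoro group contributes, and whether a hydroxyl group or a nitrile in its place would keep the gain seen with compound 3.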